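A few compounds are considered here, and "the series" means these few. Any claim that something is new, unique, unknown or untested is made for them only; others in the source may bear on it.

Within the data shown here, compounds with a number so far: compound 1, `COc1ccc([C@H]2C=C(CC/C=C(\C)CCC=C(C)C)C(=O)O2)cc1`, with 6210 nM in an assay on microsomes from liver for inhibition of 3-hydroxy-3-methylglutaryl-coenzyme A reductase (Sus scrofa), read by colorimetric assay; a lower number here means a stronger inhibitor, a higher number a weaker inhibitor; and compound 2, `CC(C)=CCC/C(C)=C/CCC1=C[C@H](c2cc(F)ccc2F)OC1=O`, with 25100 nM in this assay.

Compound 2 holds the highest of the two numbers. Among the measured compounds shown here, its nearest neighbour is compound 1, and the only step on record runs between them: a 4.0-fold higher number from compound 1 to compound 2 (0.61 log units; beyond the scatter). That step concerns the same saturated ring carbon that is changed in the step to compound 3, so it is the only one that bears on the new compound.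

Compound 3 is `CC(C)=CCC/C(C)=C/CCC1=C[C@H](c2ccccc2O)OC1=O`. Relative to compound 2 the change is 2-hydroxyphenyl in place of 2,5-difluorophenyl on a saturated ring carbon.

For the measured compounds named here, the one relevant step shows that swapping the aromatic group at this position can move the number by a modest amount. The direction for the 2-hydroxyphenyl group cannot be read from compound 1 and compound 2 alone, since neither carries a hydrogen-bond donor on that ring. Taking compound 2 as the starting point, compound 3 is expected to give a somewhat lower number in this assay, with the step of a 2.1-fold lower number from compound 2 to compound 3 (0.32 log units; beyond the scatter) as a reasonable expectation. The estimate for compound 3 is therefore 12000 nM, with a range from 3500 nM to 40000 nM.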

Compound 3, half-maximal inhibitory concentration: 6760 nM
Estimate against measurement, compound 3: 1.8-fold (0.25 log units) above; measured number inside the range.
By their numbers in this assay, from the lowest: compounds 1 and 3 (each within the scatter of the next); then compound 2.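

On the saturated ring carbon next to the ring oxygen, the 2-hydroxyphenyl group recovers what the 2,5-difluorophenyl group had lost in this assay, giving a 3.7-fold lower number from compound 2 to compound 3 (0.57 log units; beyond the scatter), so the earlier rise in the number is not a fixed feature of moving away from the 4-methoxyphenyl group. The 2-hydroxyphenyl and 4-methoxyphenyl groups cannot be told apart here, with a 1.1-fold higher number from compound 1 to compound 3 (0.04 log units; within the scatter), which leaves compound 2 as the only one of the three that stands apart, while two differently substituted rings, each bearing an oxygen, sit level. Nothing measured here accounts for the difference between the fluorine-bearing ring and the two oxygen-bearing rings.

The compounds shown do not separate the kind of substituent from its place on the ring, as a 4-hydroxyphenyl or 2-methoxyphenyl group at this carbon would, and they give no reference point from an unsubstituted phenyl ring. They also leave open whether a 2-aminophenyl group would sit with these two oxygen-bearing rings, and whether a shorter chain on the far side of the core would keep the number where it is.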